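A few compounds are considered here, and "the series" means these few. Any claim that something is new, unique, unknown or untested is made for them only; others in the source may bear on it.

Measured compounds:
- compound 1, `COc1ccc(C(=O)Nc2ccccc2C)cc1OC1CCCC1`, 300 nM in an assay on isolated protein for inhibition of phosphodiesterase 4A (Sus scrofa); a lower number here means a stronger inhibitor, a higher number a weaker inhibitor
- compound 2, `COc1ccc(C(=O)Nc2ccccc2Cl)cc1OC(=O)C(C)(C)C`; in this assay compound 2 reaches only a limit of the assay, > 1000000 nM, and gives no number
- compound 3, `COc1ccc(C(=O)Nc2ccccc2Cl)cc1OC(C)=O`, 70000 nM in this assay

Among the measured compounds shown here, compound 1 has the lowest number of the two numbers known; compound 3 stands far above it, and compound 2 sits at the limit (the limit of > 1000000 nM in this assay, at which 1 of the 3 values shown sits).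

The unmeasured compound 4 is `COc1ccc(C(=O)Nc2ncccc2C)cc1OC1CCCC1`. It differs from compound 1 only on the amide-type nitrogen: 3-methylpyridin-2-yl in place of 2-methylphenyl on an amide-type nitrogen. The shared core of compound 1, with its methoxy and cyclopentyloxy groups, stays untouched.

For the measured compounds named here, the one measured step, an at least 14-fold lower number from compound 2 to compound 3 (1.15 log units; beyond the scatter), concerns the ester on the core and not the group on the amide nitrogen, so no measured step bears directly on the change to compound 4. The change keeps the ring size and the methyl, and adds one ring nitrogen. Without a comparable step among the known compounds, a step of no size beyond the scatter is the plainest expectation, and the estimate is therefore placed near compound 1 with a wide range. The step of a 1.5-fold lower number from compound 1 to compound 4 (0.18 log units; within the scatter) is what this estimate means. Compound 4 is expected to give 200 nM, between 30 nM and 1500 nM.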

Compound 4, half-maximal inhibitory concentration: 3100 nM
Compound 4: the middle estimate sits 16-fold (1.19 log units) below what was measured; measured number above the stated range.
By their numbers in this assay, from the lowest: compound 1; then compound 4; then compound 3. At a limit, above all of these: compound 2.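

Placing 3-methylpyridin-2-yl instead of 2-methylphenyl on the amide-type nitrogen gives a 10-fold higher number from compound 1 to compound 4 (1.01 log units; beyond the scatter) in this assay, so this place responds strongly to a change of one ring atom, although the ring size, the methyl and the count of heavy atoms stay the same. Among the compounds shown here, this is the first measured step at this place, since the earlier step concerned only the ester on the core. Nothing measured among these compounds accounts for this weakening.

From the compounds shown here alone, it remains open how a plain phenyl or a cyclohexyl group on the amide-type nitrogen would fare in this assay. Also open, going by these compounds, is whether a longer chain, such as butoxy, in place of the cyclopentyloxy group would change the picture for the 3-methylpyridin-2-yl series.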